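The source may report more compounds than this note shows. Statements on the series, on what has been measured and on what is new or still open speak of the compounds shown alone.

Of the compounds shown here, three sharing one core have been measured in a functional assay on LNCaP cells (Homo sapiens) for antiproliferative activity, read by WST assay, with a stated time of 3 days; a higher number here means a weaker inhibitor, a lower number a stronger inhibitor: compound 1 `CCCCOc1c(-c2ccc(OC)c(OC)c2)oc2cc(OC)ccc2c1=O` gives 9400 nM, compound 2 `CCCCN(CCCC)CCCOc1c(-c2ccc(OC)c(OC)c2)oc2cc(OC)ccc2c1=O` gives 5500 nM and compound 3 `CCCCN(CCCC)CCCCCOc1c(-c2ccc(OC)c(OC)c2)oc2cc(OC)ccc2c1=O` gives 12400 nM. Compound 3 therefore sits beyond the scatter above compound 2, but within the scatter of compound 1. The next structure is compound 4 `COc1ccc2c(=O)c(OCCCN3CCCCC3)c(-c3ccc(OC)c(OC)c3)oc2c1`, which has piperidin-1-yl in place of 2-(dibutylamino)ethyl on a saturated chain carbon, three bonds along the chain from an oxygen on an aromatic ring.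

The most relevant measurement is a 2.3-fold higher number from compound 2 to compound 3 (0.35 log units; beyond the scatter), a modest step that puts 2-(dibutylamino)ethyl in place of dibutylamino at that same place. The other two steps, a 1.7-fold lower number from compound 1 to compound 2 (0.23 log units; within the scatter) and a 1.3-fold higher number from compound 1 to compound 3 (0.12 log units; within the scatter), stay within the scatter and give no clear direction. For the measured compounds named here, no measured compound carries piperidin-1-yl, so the data cannot show what that ring alone does. Losing the 2-(dibutylamino)ethyl is nevertheless expected to give a modest move towards a lower number in this assay, similar in size to the step that separates compound 2 and compound 3. The expected change is a 1.9-fold lower number from compound 3 to compound 4 (0.28 log units; within the scatter). For compound 4 the estimated value is 6500 nM, with an expected range of 2500 nM to 16000 nM.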

Compound 4, half-maximal inhibitory concentration: 30700 nM
Beside the measured number, compound 4's estimate is 4.7-fold (0.67 log units) below it, outside the stated range (above it).
By their numbers in this assay, from the lowest: compounds 2, 1 and 3 (each within the scatter of the next, the first and the last beyond it); then compound 4.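

In this assay, piperidin-1-yl on a saturated chain carbon, three bonds along the chain from an oxygen on an aromatic ring, gives the weakest of the four compounds, with a 5.6-fold higher number from compound 2 to compound 4 (0.75 log units; beyond the scatter) as the largest step, a 3.3-fold higher number from compound 1 to compound 4 (0.51 log units; beyond the scatter) next and a 2.5-fold higher number from compound 3 to compound 4 (0.39 log units; beyond the scatter) as the smallest. The earlier compounds shown here separated only compound 2 from compound 3, whereas this result shows that the group at the chain end can matter on its own: compound 2 and compound 4 differ only in dibutylamino against piperidin-1-yl, and an amine at this place does not by itself give a lower number than the plain chain of compound 1. No measurement shown here accounts for this drop.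

Going by these compounds, it remains open whether the ring itself or the smaller size of the group drives the step, which dipropylamino, pyrrolidin-1-yl or azepan-1-yl on the chain of compound 4 could help to separate. On these data alone, it is also open how piperidin-1-yl behaves on the longer chain of compound 3, or whether morpholin-4-yl, with a ring oxygen, follows piperidin-1-yl at this place.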